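Swapping the ester alkyl group on a thiophene-bearing dihydropyrimidinone

A few compounds are considered here, and "the series" means these few. Any claim that something is new, unique, unknown or untested is made for them only; others in the source may bear on it.

This account follows two members of a small series that share one core. Compound 1 `CC1=C(C(=O)OC(C)(C)C)C(c2ccco2)NC(=O)N1C` carries a tert-butyl ester and a furan ring; compound 2 `CCCOC(=O)C1=C(C)N(C)C(=O)NC1c1ccsc1` carries a propyl ester and a thiophene ring. In an assay on membranes from CHO cells for displacement of a labelled ligand from adenosine receptor A1 (Homo sapiens), read by scintillation counting, with a stated time of 60 min, tested at 1 uM (on this read-out lower numbers stand for less inhibition and higher numbers for more inhibition at the one concentration tested (going by the name of the read-out)), compound 1 gives 44%, whereas compound 2 gives 2%, the lower of the two numbers and a gap to compound 1 that lies beyond the usual scatter.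

The next compound, compound 3 `CC1=C(C(=O)OC(C)(C)C)C(c2ccsc2)NC(=O)N1C`, keeps the thiophene ring of compound 2 and changes only the ester: tert-butyl in place of propyl on an oxygen next to a carbonyl group. Within the data shown here, no measured pair in this set isolates that exact change, so its size has to be judged from what is at hand. Compound 1, which also bears tert-butyl on the oxygen next to the carbonyl group, gives 44%, so a rise in this assay is expected for compound 3, though a modest one given that its ring differs from compound 1. The expected step is a number 20 percentage points higher from compound 2 to compound 3 (beyond the scatter). Compound 3 is therefore estimated at 22%, with a likely range from 4% to 48%.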

Compound 3, a percentage reported as inhibition, at one concentration (the size of the read-out at that concentration, not a potency): 18%
Estimate against measurement, compound 3: 4 percentage points above; the measured number falls inside the stated range.
By their numbers in this assay, from the lowest: compound 2; then compound 3; then compound 1.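

With the thiophen-3-yl ring held constant, the ester group now has a step of its own: in this assay, tert-butyl in place of propyl on an oxygen next to a carbonyl group gives a number 16 percentage points higher from compound 2 to compound 3 (beyond the scatter) and so shows that this position alone moves the read-out beyond the usual scatter. With the tert-butyl ester held constant, thiophen-3-yl in place of furan-2-yl on a saturated ring carbon gives a number 26 percentage points lower from compound 1 to compound 3 (beyond the scatter) and shows that the ring change also matters on its own, so the wide gap between compound 1 and compound 2 cannot be assigned to either place alone. Nothing at hand explains either step.

The compounds shown leave open whether a free carboxylic acid, an ethyl ester or a longer chain such as hexyl on that oxygen would continue or break the rise seen with tert-butyl. They also leave open whether the two steps would hold on other pairings, such as a propyl ester carrying furan-2-yl, or with a phenyl ring in place of either ring shown.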